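The source may report more compounds than this note shows. Statements on the series, on what has been measured and on what is new or still open speak of the compounds shown alone.

Measured compounds:
compound 1 `CCCCC(Sc1nc(Cl)cc(Nc2nc(-c3ccc(Cl)cc3)cs2)n1)C(=O)O` — 3800 nM
compound 2 `O=C(O)C(Sc1nc(Cl)cc(Nc2nc(-c3ccc(Cl)cc3)cs2)n1)c1cccc2ccccc12` — 700 nM
compound 3 `CCCCCCC(Sc1nc(Cl)cc(Nc2nc(-c3ccc(C)cc3)cs2)n1)C(=O)O` — 3000 nM

In an assay for inhibition of Polyunsaturated fatty acid 5-lipoxygenase (Homo sapiens), read by HPLC, with a stated time of 10 min (a higher number here means a weaker inhibitor, a lower number a stronger inhibitor), compound 3 gives 3000 nM, the second highest of the three numbers. Its nearest neighbour is compound 1, whose value of 3800 nM lies within the usual scatter of it, so the two cannot be ordered; compound 2, with 700 nM, sits clearly lower. Compound 4 `CCCCCCC(Sc1nc(Cl)cc(Nc2nc(-c3cccc4ccccc34)cs2)n1)C(=O)O` has not been measured in this assay. It differs from compound 3 in one place: naphthalen-1-yl in place of 4-methylphenyl on an aromatic carbon. Going by the values given here, the only measured step that involves the entering group is a 5.4-fold lower number from compound 1 to compound 2 (0.73 log units; beyond the scatter), where naphthalen-1-yl replaced butyl on the saturated chain carbon. Among the compounds with values here, that step lies at a different place in the molecule, so it only loosely bears on the present change; no step at the aromatic carbon of the five-membered ring is available. A modest lowering is therefore expected, smaller than the measured step and uncertain in size, amounting to a 2.0-fold lower number from compound 3 to compound 4 (0.30 log units; within the scatter). Compound 4 is estimated at 1500 nM, with a range from 500 nM to 5000 nM.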

Compound 4, half-maximal inhibitory concentration: 700 nM
Compound 4: middle estimate off by 2.1-fold (0.33 log units), on the high side; low and high end bracket the measured number.
By their numbers in this assay, from the lowest: compounds 2 and 4 (each within the scatter of the next); then compounds 3 and 1 (each within the scatter of the next).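

In this assay, going by these compounds alone, naphthalen-1-yl in place of 4-methylphenyl gives a 4.3-fold lower number from compound 3 to compound 4 (0.63 log units; beyond the scatter), the first measured step on this aromatic carbon of the five-membered ring. Until now, the only measured effect of naphthalen-1-yl was at the saturated chain carbon, in a 5.4-fold lower number from compound 1 to compound 2 (0.73 log units; beyond the scatter), so the number is now seen to respond to this group at two separate places in the molecule, each time beyond the scatter. Nothing available explains why the number falls at this position.

On these data alone, it remains open whether naphthalen-2-yl, or a phenyl ring carrying a methoxy group, on this aromatic carbon would give a similar step. Also open, as far as these compounds go, is whether naphthalen-1-yl at both places together would lower the number further than either change alone.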